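Hydroxy in place of methyl on the amide chain

The compounds below may be only part of what the source reports. "The series", "measured", "known", "first", "only" and "open" are said of these compounds alone.

Measured compounds:
compound 1 `CCCCC(=O)Nc1cc(Oc2ccc(Nc3nccc4[nH]cc(-c5ccc(F)cc5)c(=O)c34)cc2F)ccn1`: 62.7%
compound 2 `CC(C)(C)C(=O)Nc1cc(Oc2ccc(Nc3nccc4[nH]cc(-c5ccc(F)cc5)c(=O)c34)cc2F)ccn1`: 62.5%

In a functional assay on MKN-45 cells (Homo sapiens) for antiproliferative activity, read by MTT assay, with a stated time of 72 h, tested at 10 uM (on this read-out lower numbers stand for less inhibition and higher numbers for more inhibition at the one concentration tested (going by the name of the read-out)), compound 1 gives 62.7%, and compound 2 gives 62.5%. Among the measured compounds shown here, on these two numbers compound 2 stands together with compound 1, the only measured step being a number 0.2 percentage points lower from compound 1 to compound 2 (within the scatter), which is inside the scatter; the two compounds cannot be told apart on this read-out.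

Compound 3 `CC(C)(O)C(=O)Nc1cc(Oc2ccc(Nc3nccc4[nH]cc(-c5ccc(F)cc5)c(=O)c34)cc2F)ccn1` differs from compound 2 in one place: hydroxy in place of methyl on a saturated chain carbon bound to a carbonyl carbon and two saturated chain carbons. For the measured compounds named here, the only measured step, a number 0.2 percentage points lower from compound 1 to compound 2 (within the scatter), changes the chain on the carbonyl carbon from butyl to tert-butyl without bringing in a hydroxy, so it bears on the present change only loosely, and it shows no movement beyond the scatter. Going by the values given here, no measured step introduces a hydrogen-bond donor or acceptor at this position, so the data give no direct guide for compound 3.

Compound 3 is therefore expected to give about 60% in this assay, within a range from 45% to 75%. The step that estimate means, a number 2.5 percentage points lower from compound 2 to compound 3 (within the scatter), is expected to stay within the scatter, with the range widened for the untested hydroxy.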

Compound 3, a percentage reported as inhibition, at one concentration (the size of the read-out at that concentration, not a potency): 57.8%
For compound 3 the middle estimate is 2.2 percentage points above the measured one; measured number inside the range.
By their numbers in this assay, from the lowest: compounds 3, 2 and 1 (each within the scatter of the next).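

In this assay the exchange of methyl for hydroxy on this saturated chain carbon brings in a hydrogen-bond donor and a hydrogen-bond acceptor, and it gives a number 4.7 percentage points lower from compound 2 to compound 3 (within the scatter) on the read-out. The wider replacement of butyl by 1-hydroxy-1-methylethyl on the carbonyl carbon reads the same way, with a number 4.9 percentage points lower from compound 1 to compound 3 (within the scatter) as its step, so compounds 1, 2 and 3 cannot be told apart on this read-out, and the amide chain now shows no movement beyond the scatter with a hydroxy as well as with chains of carbon alone. The material at hand holds no measurement that would account for this result.

From the compounds shown here alone, whether an amine, a carboxylic acid or a methoxy on the same carbon would also stay within the scatter remains open, as does the outcome for a longer chain carrying its hydroxy further from the carbonyl. Going by these compounds, all three numbers stand at a single concentration, so how these compounds would compare at other concentrations also remains open.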